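Bromobenzyl in place of cyclohexylcarbonyl on the piperidine nitrogen

This account rests on a few compounds, and the source may have more. Where it says the series, first, only, none or still open, it means among the compounds named here.

Compound 1 `O=C(CCCC1CCN(C(=O)C2CCCCC2)CC1)c1ncco1` carries a cyclohexylcarbonyl on the ring amine nitrogen; in an assay on isolated protein for inhibition of Fatty-acid amide hydrolase 1 (Homo sapiens) (a higher number here means a weaker inhibitor, a lower number a stronger inhibitor), compound 1 gives 45 nM. Among the three measured compounds it holds the second highest number: compound 3 `COc1cccc(CN2CCC(CCCC(=O)c3ncco3)CC2)c1` gives 34 nM, which lies within the scatter of compound 1, while compound 2 `Cc1ccc(CN2CCC(CCCC(=O)c3ncco3)CC2)cc1` gives 400 nM, a number beyond the scatter.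

Compound 4 `O=C(CCCC1CCN(Cc2ccc(Br)cc2)CC1)c1ncco1` is the next case; it differs from compound 1 as follows: 4-bromobenzyl in place of cyclohexylcarbonyl on an amine nitrogen in a ring.

Among the measured compounds shown here, two measured steps bear on it. Exchanging the cyclohexylcarbonyl for a benzyl bearing a single substituent has been seen once, an 8.9-fold higher number from compound 1 to compound 2 (0.95 log units; beyond the scatter), a weakening. The placement of the substituent on that benzyl then mattered strongly, a 12-fold lower number from compound 2 to compound 3 (1.07 log units; beyond the scatter), with 3-methoxyphenyl giving the lower number. The 4-bromobenzyl of compound 4 resembles the 4-methylbenzyl of compound 2 rather than the 3-methoxyphenyl arrangement of compound 3, so compound 4 is expected to move in the same direction as compound 2, by a modest step beyond the scatter, a 5.6-fold higher number from compound 1 to compound 4 (0.74 log units; beyond the scatter). Whether bromine in place of methyl shifts the number further is not told by any measured pair; the range is set wide.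

Compound 4 is therefore estimated at 250 nM in this assay, between 80 nM and 800 nM.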

Compound 4, half-maximal inhibitory concentration: 45 nM
Compound 4: middle estimate off by 5.6-fold (0.74 log units), on the high side; the whole stated range lies above it.
By their numbers in this assay, from the lowest: compounds 3, 1 and 4 (each within the scatter of the next); then compound 2.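

On the ring amine nitrogen, 4-bromobenzyl and cyclohexylcarbonyl are not separated in this assay, with no change at the digits printed from compound 1 to compound 4 (within the scatter), so a benzyl carrying one substituent does not in itself weaken inhibition in this series; compound 2 is the only benzyl shown that goes against this. The change on the aromatic carbon matters strongly, with bromo in place of methyl giving an 8.9-fold lower number from compound 2 to compound 4 (0.95 log units; beyond the scatter), while the 4-bromophenyl and 3-methoxyphenyl groups remain unseparated, with a 1.3-fold higher number from compound 3 to compound 4 (0.12 log units; within the scatter), so the low numbers do not depend on the 3-methoxyphenyl arrangement alone. No measurement at hand explains the gap between bromo and methyl on this aromatic carbon.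

Still open, on these data alone, is whether chloro, trifluoromethyl or a nitrile in place of the bromo would stay with compound 4 or fall towards compound 2 in this assay. Equally open, as far as these compounds go, is how the core of compound 1 responds to a sulfonyl or a urea in place of the cyclohexylcarbonyl on the ring amine nitrogen.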